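A few compounds are considered here, and "the series" means these few. Any claim that something is new, unique, unknown or untested is made for them only; others in the source may bear on it.

Three compounds have been tested in a functional assay on CCRF-CEM cells (Homo sapiens) for cytotoxicity, read by MTT assay, with a stated time of 72 h; on this read-out higher numbers stand for weaker inhibition of growth and lower numbers for stronger inhibition of growth:

Compound 1 `C[Se]c1nc(N)c2ccccc2n1` gives a limit of the assay, > 100000 nM.
Compound 2 `CCCCC[Se]c1nc(NCc2ccc(SC)cc2)c2ccccc2n1` gives 83900 nM.
Compound 3 `CSc1nc(NCc2ccccc2)c2ccccc2n1` gives a limit of the assay, > 100000 nM.

Compound 1 therefore stands at the edge of what this assay can report: its value is only a limit, not a measured number. The same holds for compound 3, so that two of the three values shown sit at the limit of > 100000 nM in this assay, at which 2 of the 3 values shown sit. Only compound 2 returns a number, and that number lies close to the limit, so none of the three compounds inhibits growth strongly in this assay. Among the measured compounds shown here, with no pair of measured compounds differing in a single place, no step between them can be sized here; the three values only show that all sit in the weak range.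

Compound 4 `Nc1nc([SeH])nc2ccccc12` is the compound now to be measured. It differs from compound 1 by hydrogen in place of methyl on a selenium, a small change at the edge of a shared core. With compound 1 already at a limit, no step beyond the usual scatter is expected, and the most likely outcome is that compound 4 again reaches only the limit. The estimate for compound 4 in this assay is 130000 nM, with a range from 40000 nM to 400000 nM, which means an expected step that the limit leaves unreadable from compound 1 to compound 4.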

Compound 4, concentration for total growth inhibition: 52400 nM
Estimate against measurement, compound 4: 2.5-fold (0.39 log units) above; the range from low to high includes it.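

Hydrogen in place of methyl on a selenium gives an at least 1.9-fold lower number from compound 1 to compound 4 (0.28 log units; that floor lies within the scatter) in this assay. This is the first step among these compounds that can be sized at all, and it gives the first sign of how this position on the shared core responds to a change, since the compound with hydrogen on the selenium returns a real number instead of a limit; even so, the step's floor alone does not establish a change beyond the usual scatter, and the true gap may be larger. Compound 1 gives only a limit, and because of that the step has a floor and no exact size: the limit of > 100000 nM in this assay, at which 2 of the 4 values shown sit.

The compounds shown compare just hydrogen and methyl at this position, so it remains open whether an ethyl group, a longer chain or a chain ending in a carboxylic acid on the selenium would give a clearly lower or higher number in this assay. From the compounds shown here alone, it also remains open whether the same swap of methyl for hydrogen would give a comparable step in a compound that carries a benzyl group elsewhere on the core.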